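This account rests on a few compounds, and the source may have more. Where it says the series, first, only, none or still open, it means among the compounds named here.

Measured compounds:
- compound 1, `CC/C=C\CC1C(=O)C=CC1CC(=O)OC`: 19000 nM
- compound 2, `CC/C=C\C[C@H]1C(=O)C=C[C@H]1CC(=O)OCC`: 20000 nM

In a functional assay on RAW264.7 cells (Mus musculus) for inhibition, read by ELISA, with a stated time of 24 h (on this read-out higher numbers stand for an effect only at larger amounts of compound and lower numbers for an effect already at smaller amounts), compound 1 gives 19000 nM, and compound 2, which carries an ethyl ester in place of the methyl ester, gives 20000 nM. On the numbers shown compound 2 stands beside compound 1: the gap between the two lies within the scatter of repeated measurements, so the two compounds cannot be told apart on this read-out.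

Compound 3, `CC/C=C\C[C@H]1C(=O)C=C[C@H]1CC(=O)OCCC`, carries the same change one step further. It differs from compound 2 by methyl in place of hydrogen on a saturated chain carbon, two bonds along the chain from an oxygen next to a carbonyl group. Since the earlier lengthening of the ester chain, from compound 1 to compound 2, produced nothing beyond the scatter, the same outcome is expected here: a step from compound 2 to compound 3 of about no change at the digits printed from compound 2 to compound 3 (within the scatter), that is, no change beyond the scatter in either direction.

Compound 3 is therefore expected to give about 20000 nM in this assay, with a likely range from 10000 nM to 40000 nM.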

Compound 3, half-maximal effective concentration: 23000 nM
Compound 3: the middle estimate sits 1.2-fold (0.06 log units) below what was measured; low and high end bracket the measured number.
By their numbers in this assay, from the lowest: compounds 1, 2 and 3 (each within the scatter of the next).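

In this assay the change from ethyl to propyl gives a 1.2-fold higher number from compound 2 to compound 3 (0.06 log units; within the scatter) and so does not separate the two compounds. Among these compounds, this is the first comparison here between two compounds that differ in one place only, and it shows that methyl in place of hydrogen on a saturated chain carbon, two bonds along the chain from an oxygen next to a carbonyl group, leaves the read-out within the scatter. No measurement at hand offers an explanation for this result.

Going by these compounds, whether a longer chain such as octyl, a benzyl ester, or a carboxylic acid in place of the ester would move the number beyond the scatter remains open. Also open is what changes elsewhere on the shared core would do, since all the differences shown lie in the ester chain.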